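A few compounds are considered here, and "the series" means these few. Any claim that something is new, unique, unknown or untested is made for them only; others in the source may bear on it.

Among the compounds with values here, compound 3, with the structure `Cc1nn(-c2ncnc3nc[nH]c23)c2c1C(OCc1cc(F)cc3c1OCOC3)CC(=O)N2`, gives 30 nM in a functional assay on HEK293 cells for agonist activity at G-protein coupled receptor 39 (Homo sapiens), read by scintillation proximity assay and inositol phosphate accumulation, with a stated time of 75 min (on this read-out lower numbers stand for an effect already at smaller amounts and higher numbers for an effect only at larger amounts of compound), and stands lowest of the three compounds measured so far. Compound 1 `Cc1cc(C)n(CCOC2CC(=O)Nc3c2c(C)nn3-c2ncnc3nc[nH]c23)n1` gives 2000 nM in this assay, and compound 2 `Cc1nn(-c2ncnc3nc[nH]c23)c2c1C(OCCn1nccc1C)CC(=O)N2` gives 1620 nM. The two small five-membered side groups of compound 1 and compound 2 are close to each other, as a 1.2-fold lower number from compound 1 to compound 2 (0.09 log units; within the scatter) shows, while the change to the larger bicyclic group brought a 67-fold lower number from compound 1 to compound 3 (1.82 log units; beyond the scatter) and a 54-fold lower number from compound 2 to compound 3 (1.73 log units; beyond the scatter).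

Compound 4 `Cc1nn(-c2ncnc3nc[nH]c23)c2c1C(OCC(C)C)CC(=O)N2` is the next compound to be measured. Its change from compound 3 is a group of 3 heavy atoms (3 carbon; no ring) in place of a group of 11 heavy atoms (8 carbon, 2 oxygen, 1 fluorine; one six-membered non-aromatic ring with 2 hetero atoms, one six-membered aromatic ring of carbon only), on a saturated chain carbon bound to an oxygen on a saturated carbon. The two measured steps that bear on this are those from compound 1 and compound 2 to compound 3, both large and both in the direction of lower numbers when the bicyclic group enters. Compound 4 now loses that group and receives an isopropyl, a group with no ring and no acceptors, smaller even than the side groups of compound 1 and compound 2. The expectation for compound 4 is therefore a large step back toward higher numbers in this assay, roughly undoing the gain seen in compound 3, which is a 50-fold higher number from compound 3 to compound 4 (1.70 log units; beyond the scatter). The estimate for compound 4 in this assay is 1500 nM, expected to lie between 400 nM and 6000 nM.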

Compound 4, half-maximal effective concentration: 111 nM
Beside the measured number, compound 4's estimate is 14-fold (1.13 log units) above it; the whole stated range lies above it.
By their numbers in this assay, from the lowest: compound 3; then compound 4; then compounds 2 and 1 (each within the scatter of the next).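

Replacing the larger group with isopropyl brings only a modest rise in this assay, a 3.7-fold higher number from compound 3 to compound 4 (0.57 log units; beyond the scatter), so a ring at this place, on a saturated chain carbon bound to an oxygen on a saturated carbon, is not required for a number well under those of compound 1 and compound 2. Isopropyl in place of (5-methyl-1H-pyrazol-1-yl)methyl gives a 15-fold lower number from compound 2 to compound 4 (1.16 log units; beyond the scatter), and isopropyl in place of (3,5-dimethyl-1H-pyrazol-1-yl)methyl gives an 18-fold lower number from compound 1 to compound 4 (1.26 log units; beyond the scatter), which ties the high numbers of those two compounds to the pyrazolylmethyl groups they carry and not to a lack of bulk. Compound 3 still has the lowest number of the four, but size alone does not set the order, since compound 4, with the smallest group, stands lower than compound 1 and compound 2, whose groups are larger.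

As far as these compounds go, it remains open whether a straight butyl chain, a cyclohexyl ring or a plain benzyl group at this place would fall nearer compound 3 or compound 4, and how an amine or a carboxylic acid at the end of the chain would fare. No measurement at hand accounts for this order.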